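A few compounds are considered here, and "the series" means these few. Any claim that something is new, unique, unknown or untested is made for them only; others in the source may bear on it.

Measured compounds in a functional assay on CHO cells for inhibition of transient receptor potential cation channel subfamily V member 1 (Homo sapiens); a lower number here means a stronger inhibitor, a higher number a weaker inhibitor:
Compound 1 `Cc1ccc(/C=C/C(=O)Nc2ccc3c(c2)OCCO3)cc1` gives 210 nM.
Compound 2 `CCCCc1ccc(/C=C/C(=O)Nc2ccc3c(c2)OCCO3)cc1` gives 360 nM.
Compound 3 `O=C(/C=C/c1ccc(C(F)(F)F)cc1)Nc1ccc2c(c1)OCCO2` gives 46 nM.

Compound 3 is the strongest inhibitor of the three, with steps beyond the scatter to both other compounds: a 4.6-fold lower number from compound 1 to compound 3 (0.66 log units; beyond the scatter) and a 7.8-fold lower number from compound 2 to compound 3 (0.89 log units; beyond the scatter). The step of a 1.7-fold higher number from compound 1 to compound 2 (0.23 log units; within the scatter) lies within the scatter, so methyl and butyl on the aromatic carbon are not told apart by these numbers.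

Compound 4 `O=C(/C=C/c1ccc(O)cc1)Nc1ccc2c(c1)OCCO2` differs from compound 3 in one place: hydroxy in place of trifluoromethyl on an aromatic carbon. The two steps that bear on it both end at trifluoromethyl and both show that leaving it for an alkyl group gives a higher number. Within the data shown here, no measured compound carries hydroxy or any group with a hydrogen-bond donor at this position, so the direction of the step is read from those two steps only and its size is uncertain. A higher number than for compound 3 is expected, probably of modest size, and the range is set wide.

For compound 4 the expected value is 400 nM, with a range from 120 nM to 1500 nM. The expected step of an 8.7-fold higher number from compound 3 to compound 4 (0.94 log units; beyond the scatter) is an estimate, not a measurement.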

Compound 4, half-maximal inhibitory concentration: > 4000 nM
Compound 4 gave a limit, no number; the forecaster's own chance of this, stated with the estimate: 5%; at least 10-fold (1.00 log units) between middle value and limit.
By their numbers in this assay, from the lowest: compound 3; then compounds 1 and 2 (each within the scatter of the next). At a limit, above all of these: compound 4.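

In this assay compound 4 is held only by a limit and not by a number: the limit of > 4000 nM in this assay, at which 1 of the 4 values shown sits.
The earlier swaps at this aromatic carbon, para to a large group, stayed modest or within the scatter, whereas hydroxy gives large steps from all three groups: an at least 86-fold higher number from compound 3 to compound 4 (1.93 log units; beyond the scatter) and an at least 19-fold higher number from compound 1 to compound 4 (1.27 log units; beyond the scatter) and also an at least 11-fold higher number from compound 2 to compound 4 (1.04 log units; beyond the scatter) in a series where it is the only group shown with a hydrogen-bond donor.
The position therefore tolerates methyl, butyl and trifluoromethyl far better than hydroxy, so the alkyl swaps gave no measure of how much can be lost here.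

Going by these compounds, whether the loss follows the hydroxy hydrogen or the oxygen stays open, and a methoxy group or an amine at this position would separate the two. On these data alone, whether a nitrile or a chlorine matches trifluoromethyl also stays open.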